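Bromo in place of hydrogen on the core of compound 1

The source may report more compounds than this note shows. Statements on the series, on what has been measured and on what is new or still open speak of the compounds shown alone.

Compound 1, `COc1ccc(N/C(CCNC2=CC(=O)c3ccccc3C2=O)=N\S(=O)(=O)c2ccc(C)cc2)cc1OC`, gives 17800 nM in a functional assay on DU-145 cells (Homo sapiens) for cytotoxicity, read by MTT assay, with a stated time of 48 h; a lower number here means a stronger inhibitor, a higher number a weaker inhibitor. Within the data shown here, only one other compound has been measured: compound 2, `Cc1ccc(S(=O)(=O)/N=C(/CCNC2=CC(=O)c3ccccc3C2=O)Nc2ccc(Cl)cc2Cl)cc1`, gives 18600 nM, and the two numbers cannot be told apart, since a 1.0-fold higher number from compound 1 to compound 2 (0.02 log units; within the scatter). Among the measured compounds shown here, the single measured step thus exchanges the aryl group on the amine nitrogen and leaves the read-out unmoved.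

Compound 3, `COc1ccc(N/C(CCNC2=C(Br)C(=O)c3ccccc3C2=O)=N\S(=O)(=O)c2ccc(C)cc2)cc1OC`, is the next compound: bromo in place of hydrogen on a double-bonded ring carbon. For the measured compounds named here, this change sits on the shared core rather than on the amine-bound aryl group, so the step from compound 1 to compound 2 does not bear on it directly; no measured pair shows what a substituent on that ring carbon does. Going by the values given here, with the one measured step flat and nothing measured on the core, the expectation for compound 3 is a step of a 1.2-fold lower number from compound 1 to compound 3 (0.07 log units; within the scatter) in this assay, without a clear direction and within the scatter or close to it. Compound 3 is therefore estimated at 15000 nM, with a range from 5000 nM to 45000 nM.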

Compound 3, half-maximal inhibitory concentration: 29600 nM
Beside the measured number, compound 3's estimate is 2.0-fold (0.30 log units) below it, and the stated range covers the measured number.
By their numbers in this assay, from the lowest: compounds 1, 2 and 3 (each within the scatter of the next).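

In this assay, among these compounds, bromo in place of hydrogen on a double-bonded ring carbon gives a 1.7-fold higher number from compound 1 to compound 3 (0.22 log units; within the scatter), the first measured step on the shared core. This ring carbon, which lies next to the ring atom that bears a large group, therefore takes a bromine atom in place of hydrogen without a change that can be told from the scatter. The core change thus reads like the exchange of the aryl group on the amine nitrogen, a 1.0-fold higher number from compound 1 to compound 2 (0.02 log units; within the scatter), and in this small set neither place has yet produced a step beyond the scatter. No measurement is available that accounts for the result.

With bromo as the only substituent shown on this ring carbon, it remains open how an amine, a methoxy group or a longer chain placed there would read in this assay. On these data alone, it also remains open whether bromo on this carbon would read the same when combined with the 2,4-dichlorophenyl group of compound 2, which would show whether the two places act independently of each other.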